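A tetrahydroisoquinoline amide awaiting its reading

The source may hold more compounds than are shown below. What is called first, only, known or untested is meant among the compounds shown, and "the series" means these compounds.

Values in an ADME assay on MT4 cells (Homo sapiens) for cytotoxicity, read by MTT assay; a higher number here means that more compound is tolerated, a lower number that less compound is tolerated:
- compound 1 `Cc1ccccc1NC(=O)CSc1nncnc1-c1cccc2ccccc12`: 158000 nM
- compound 2 `O=C(CSc1nncnc1-c1ccccc1Cl)N1CCc2ccccc2C1`: >= 38000 nM (a limit)
- compound 3 `O=C(CSc1nncnc1-c1cccc2ccccc12)Nc1cccnc1Cl`: 44000 nM

Compound 3 holds the lower of the two values that are actual numbers. Going by the values given here, the only measured step is a 3.6-fold lower number from compound 1 to compound 3 (0.56 log units; beyond the scatter), which brought in its 2-chloropyridin-3-yl. Compound 4 `O=C(CSc1nncnc1-c1cccc2ccccc12)N1CCc2ccccc2C1` places 1,2,3,4-tetrahydroisoquinolin-2-yl in place of (2-chloropyridin-3-yl)amino on a carbonyl carbon. Compound 2 carries the same group, and its value is only a limit: the limit of >= 38000 nM in this assay, at which 1 of the 3 values shown sits. Given a 3.6-fold lower number from compound 1 to compound 3 (0.56 log units; beyond the scatter), leaving the group of compound 3 is expected to give a modest rise. The expected change is a 2.3-fold higher number from compound 3 to compound 4 (0.36 log units; beyond the scatter). Compound 4 is estimated at 100000 nM, within an expected range of 40000 nM to 250000 nM.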

Compound 4, half-maximal cytotoxic concentration: 13000 nM
Compound 4: the middle estimate sits 7.7-fold (0.89 log units) above what was measured; the whole stated range lies above it.
By their numbers in this assay, from the lowest: compound 4; then compound 3; then compound 1.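

In this assay the carbonyl carbon tolerates a change that takes away the amide hydrogen and still lowers the number: 1,2,3,4-tetrahydroisoquinolin-2-yl gives a 3.4-fold lower number from compound 3 to compound 4 (0.53 log units; beyond the scatter) and a 12-fold lower number from compound 1 to compound 4 (1.08 log units; beyond the scatter). The aromatic carbon also counts, since naphthalen-1-yl in place of 2-chlorophenyl gives an at least 2.9-fold lower number from compound 2 to compound 4 (0.46 log units; beyond the scatter). That step rests on compound 2, whose value is only a limit: the limit of >= 38000 nM in this assay, at which 1 of the 4 values shown sits. The compounds shown leave open whether the aromatic ring of 1,2,3,4-tetrahydroisoquinolin-2-yl is needed for the lower number. Piperidin-1-yl or morpholin-4-yl on the carbonyl carbon would test this.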